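A Second Methoxy Group on a Weak Amine

A few compounds are considered here, and "the series" means these few. Any claim that something is new, unique, unknown or untested is made for them only; others in the source may bear on it.

Going by the values given here, in an ADME assay on CCRF-CEM cells (Homo sapiens) for antiproliferative activity, with a stated time of 48 h (on this read-out higher numbers stand for weaker inhibition and lower numbers for stronger inhibition), compound 2 (`COc1cccc(/C=C/C(=O)c2ccc(N)cc2)c1`) gives 23000 nM, the higher of the two numbers so far. Compound 1 (`C=C(Br)C(=O)Nc1ccc(C(=O)/C=C/c2cc(OC)cc(OC)c2)cc1`) gives 2200 nM, which is clearly lower. Compound 3 (`COc1cc(/C=C/C(=O)c2ccc(N)cc2)cc(OC)c1`) is compound 2 with methoxy in place of hydrogen on an aromatic carbon, meta to a large group and meta to a methoxy group (methoxy in place of hydrogen on an aromatic carbon). Among the compounds with values here, no measured pair isolates this change, so only a modest shift toward stronger inhibition is expected. The estimated change is a 1.9-fold lower number from compound 2 to compound 3 (0.28 log units; within the scatter), roughly the size of ordinary scatter. Compound 3 is expected at 12000 nM, with a likely range from 3500 nM to 35000 nM.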

Compound 3, half-maximal inhibitory concentration: 5700 nM
Compound 3: middle estimate off by 2.1-fold (0.32 log units), on the high side; the range from low to high includes it.
By their numbers in this assay, from the lowest: compound 1; then compound 3; then compound 2.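

In this assay putting methoxy on this aromatic carbon, meta to a large group and meta to a methoxy group, gives a 4.0-fold lower number from compound 2 to compound 3 (0.61 log units; beyond the scatter) and so shifts the number toward stronger inhibition by more than the scatter. Compound 3 also allows a comparison at the nitrogen, where hydrogen in place of (1-bromoethenyl)carbonyl gives a 2.6-fold higher number from compound 1 to compound 3 (0.41 log units; beyond the scatter) and so weakens inhibition by more than the scatter. Nothing available explains either step.

From the compounds shown here alone, whether ethoxy or a hydroxyl group on this carbon would move the number further remains open. So does whether (1-bromoethenyl)carbonyl on the nitrogen of compound 2 would produce a similar step.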